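This account rests on a few compounds, and the source may have more. Where it says the series, first, only, none or still open, it means among the compounds named here.

In a functional assay on MCF7 cells (Homo sapiens) for cytotoxicity, read by MTT assay, with a stated time of 72 h (on this read-out lower numbers stand for stronger inhibition and higher numbers for weaker inhibition), three compounds sharing one core have been measured. Compound 1 `CN(C)c1ccc(C=C2C(=O)N(c3ccc(Cl)cc3)N(c3ccc(Cl)cc3)C2=O)cc1` gives > 128000 nM, which is a limit of the assay and not a number. Compound 2 `O=C1C(=Cc2ccc(Br)cc2)C(=O)N(c2ccc(Cl)cc2)N1c1ccc(Cl)cc1` gives 30400 nM, and compound 3 `COc1cccc(C=C2C(=O)N(c3ccc(Cl)cc3)N(c3ccc(Cl)cc3)C2=O)c1O` gives 26700 nM. These two values stand level, with a 1.1-fold lower number from compound 2 to compound 3 (0.06 log units; within the scatter). Both differ clearly from the limit, as an at least 4.2-fold lower number from compound 1 to compound 2 (0.62 log units; beyond the scatter) and an at least 4.7-fold lower number from compound 1 to compound 3 (0.68 log units; beyond the scatter) show.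

Compound 4 `COc1cccc(C=C2C(=O)N(c3ccc(Cl)cc3)N(c3ccc(Cl)cc3)C2=O)c1` carries one change from compound 3: hydrogen in place of hydroxy on an aromatic carbon. This places hydrogen in place of hydroxy on an aromatic carbon, turning 2-hydroxy-3-methoxyphenyl into 3-methoxyphenyl.

Going by the values given here, no measured step makes this exact change, so the evidence is indirect. Whole-group exchanges bear on it: compound 3, which has the hydroxy, and compound 2, which lacks it, remain level at a 1.1-fold lower number from compound 2 to compound 3 (0.06 log units; within the scatter). Compound 1 also lacks the hydroxy, and an at least 4.7-fold lower number from compound 1 to compound 3 (0.68 log units; beyond the scatter) shows that a group exchange at this place can matter. A step within the scatter is therefore expected in this assay, leaning slightly towards a higher number. The expected step is a 1.3-fold higher number from compound 3 to compound 4 (0.12 log units; within the scatter). For compound 4 the estimated value is 35000 nM, with an expected range from 12000 nM to 100000 nM.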

Compound 4, half-maximal inhibitory concentration: 18100 nM
For compound 4 the middle estimate is 1.9-fold (0.29 log units) above the measured one; the range from low to high includes it.
By their numbers in this assay, from the lowest: compounds 4, 3 and 2 (each within the scatter of the next). At a limit, above all of these: compound 1.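

Taking the hydroxy away from this carbon, which lies ortho to a large group and ortho to a methoxy group, gives the first direct reading of that single change: in this assay there is a 1.5-fold lower number from compound 3 to compound 4 (0.17 log units; within the scatter), so the two values stand level and the hydroxy is not required for the activity seen in this small set. The 3-methoxyphenyl group also stands level with the 4-bromophenyl group, at a 1.7-fold lower number from compound 2 to compound 4 (0.23 log units; within the scatter), so three different aromatic groups now give values within the scatter of one another. Only the 4-(dimethylamino)phenyl group stays apart, with an at least 7.0-fold lower number from compound 1 to compound 4 (0.84 log units; beyond the scatter), and that comparison rests on a limit and not on a number: the limit of > 128000 nM in this assay, at which 1 of the 4 values shown sits.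

As far as these compounds go, what the methoxy group itself contributes remains open, as a plain phenyl group would be needed to read it in a single step. From the compounds shown here alone, it is also open whether an amine or a carboxylic acid on the carbon that held the hydroxy would stay level with these values or move clearly away from them.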